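Oxime to Ketone on a Shared Thioether Core

The source may hold more compounds than are shown below. What is called first, only, known or untested is meant among the compounds shown, and "the series" means these compounds.

Of the compounds shown here, three of one series have been measured. Compound 1 `COc1ccc(-c2nnc(SCC(=O)c3ccccc3)n2-c2ccccc2)cc1OC` gives 65% in a functional assay on the whole organism (strain albino) for inhibition, with Rattus norvegicus as the target, read by paw edema, with a stated time of 4 h, at a dose of 0.28 mmol/kg by the oral route; a lower number here means less inhibition, a higher number more inhibition at the dose given (going by the name of the read-out). Compound 2 `COc1ccc(-c2nnc(SC/C(=N/O)c3ccccc3)n2-c2ccccc2)cc1OC` gives 81% in this assay, and compound 3 `CCn1c(SC/C(=N/O)c2ccccc2)nnc1-c1ccc(OC)c(OC)c1` gives 82%. The difference between compound 2 and compound 1 is a group of 8 heavy atoms (7 carbon, 1 oxygen; one six-membered aromatic ring of carbon only) in place of a group of 9 heavy atoms (7 carbon, 1 nitrogen, 1 oxygen; one six-membered aromatic ring of carbon only), on a saturated chain carbon bound to a sulfur; it went with a number 16 percentage points lower from compound 2 to compound 1 (beyond the scatter). Compound 2 and compound 3 share the rest of their structure but differ in the core by ethyl in place of phenyl on an aromatic nitrogen, with a number 1 percentage points higher from compound 2 to compound 3 (within the scatter), so the two stand level.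

Compound 4 `CCn1c(SCC(=O)c2ccccc2)nnc1-c1ccc(OC)c(OC)c1` has not yet been measured. It differs from compound 3 by a group of 8 heavy atoms (7 carbon, 1 oxygen; one six-membered aromatic ring of carbon only) in place of a group of 9 heavy atoms (7 carbon, 1 nitrogen, 1 oxygen; one six-membered aromatic ring of carbon only), on a saturated chain carbon bound to a sulfur, which is the same change, at the same place, as that from compound 2 to compound 1. Compound 4 is therefore expected to show a number 16 percentage points lower from compound 3 to compound 4 (beyond the scatter), resting on the step of a number 16 percentage points lower from compound 2 to compound 1 (beyond the scatter) seen for that change and on compound 3 being level with compound 2 as shown by a number 1 percentage points higher from compound 2 to compound 3 (within the scatter). For compound 4 the estimate in this assay is 66%, expected to lie between 55% and 77%.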

Compound 4, a percentage reported as inhibition, in the whole organism at one dose (the size of the read-out at that dose, not a potency): 73%
Compound 4: the middle estimate sits 7 percentage points below what was measured; low and high end bracket the measured number.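

Benzoyl in place of the oxime group went with a number 9 percentage points lower from compound 3 to compound 4 (within the scatter) in this assay, and the change carried to the second core with no detectable difference in the size of the step: the same change on two cores in this assay, a number 16 percentage points lower (beyond the scatter) from compound 2 to compound 1 and a number 9 percentage points lower (within the scatter) from compound 3 to compound 4, 7 percentage points apart, within the scatter of two such steps

Ethyl in place of phenyl on an aromatic nitrogen went with a number 8 percentage points higher from compound 1 to compound 4 (within the scatter), and this change also read alike on both partners: the same change on two cores in this assay, a number 1 percentage points higher (within the scatter) from compound 2 to compound 3 and a number 8 percentage points higher (within the scatter) from compound 1 to compound 4, 7 percentage points apart, within the scatter of two such steps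

This does not show that the oxime group gives a real gain on the core of compound 3, as that step alone stays within the scatter, and two pairs at a single dose cannot fix a general size for either change.

The compounds shown leave open what a longer chain than ethyl would do on an aromatic nitrogen. They also leave open how an amine or a carboxylic acid would read in place of benzoyl on a saturated chain carbon bound to a sulfur.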